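Swapping Ethyl for Methylsulfanyl at One Aromatic Carbon

This account rests on a few compounds, and the source may have more. Where it says the series, first, only, none or still open, it means among the compounds named here.

Of the compounds shown here, two have so far been measured in an assay on cells for inhibition of solute carrier family 22 member 12 (Homo sapiens), read by scintillation counting, with a stated time of 60 min, tested at 0.1 uM; a higher number here means more inhibition at the concentration tested (going by the name of the read-out), a lower number less inhibition. Compound 2 `CCc1cc(C(=O)N2CS(=O)(=O)c3ccccc32)cc(C#N)c1O` gives 36%. Compound 1 `N#Cc1cc(C(=O)N2CS(=O)(=O)c3ccccc32)cc(Cl)c1O` carries chloro where compound 2 carries ethyl; in this assay compound 1 gives 29%. The step of a number 7 percentage points higher from compound 1 to compound 2 (within the scatter) lies within the scatter, so compound 2 cannot be set apart from compound 1 on these numbers.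

Compound 3 `CSc1cc(C(=O)N2CS(=O)(=O)c3ccccc32)cc(C#N)c1O` has not yet been measured. Its change from compound 2 is methylsulfanyl in place of ethyl on an aromatic carbon. Going by the values given here, the only measured step touching this position is a number 7 percentage points higher from compound 1 to compound 2 (within the scatter), and it stayed within the scatter; no measured step brings in a methylsulfanyl group, so nothing directly guides the size of this change. The expected step is therefore a number 3 percentage points lower from compound 2 to compound 3 (within the scatter), which stays within the scatter. Compound 3 is expected to give 33% in this assay, within a range from 15% to 55%.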

Compound 3, a percentage reported as inhibition, at one concentration (the size of the read-out at that concentration, not a potency): 44%
Compound 3: middle estimate off by 11 percentage points, on the low side; measured number inside the range.
By their numbers in this assay, from the lowest: compounds 1, 2 and 3 (each within the scatter of the next, the first and the last beyond it).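

In this assay, this position now shows a difference that clears the scatter: replacing chloro with methylsulfanyl on this aromatic carbon gives a number 15 percentage points higher from compound 1 to compound 3 (beyond the scatter), whereas the earlier swap of chloro for ethyl did not clear it. Methylsulfanyl still cannot be told apart from ethyl, with a number 8 percentage points higher from compound 2 to compound 3 (within the scatter), so the two groups, which have the same number of heavy atoms, stand level on these numbers. No other measurement here bears on why the sulfur-containing group differs from chloro.

The compounds shown leave open how this position responds to a methoxy group, whose oxygen would stand where methylsulfanyl has its sulfur, or to a longer chain such as ethylsulfanyl. They also leave open what an amine at this position would do.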